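Swapping isobutyl for 4-fluorophenyl on a carbonyl carbon

The compounds below may be only part of what the source reports. "The series", "measured", "known", "first", "only" and "open" are said of these compounds alone.

Compound 1 `CC(=O)N1CCN(C(=O)N2Cc3c(NC(=O)c4ccc(F)cc4)n[nH]c3C2(C)C)CC1` gives > 10000 nM (a limit of the assay, not a number)
Compound 2 `CC1(C)c2[nH]nc(NC(=O)c3ccc(F)cc3)c2CN1C(=O)C1CCN(C2CC2)CC1` gives 380 nM
Compound 3 `CCN1CCC(C(=O)N2Cc3c(NC(=O)CC(C)C)n[nH]c3C2(C)C)CC1` gives 410 nM

All three results come from a functional assay on A2780 cells (Homo sapiens) for antiproliferative activity, read by fluorescence, with a stated time of 72 h (on this read-out lower numbers stand for stronger inhibition and higher numbers for weaker inhibition), and compound 3 stands level with compound 2, within the usual scatter of repeated measurements. Compound 4 (`CCN1CCC(C(=O)N2Cc3c(NC(=O)c4ccc(F)cc4)n[nH]c3C2(C)C)CC1`) differs from compound 3 by having 4-fluorophenyl in place of isobutyl on a carbonyl carbon. Within the data shown here, only one measured step is available, an at least 26-fold lower number from compound 1 to compound 2 (1.42 log units; beyond the scatter) and it is large, but it swaps a different group, so it says little about this change. More useful is compound 2, which also carries 4-fluorophenyl and gives (380 nM). That value lies within the scatter of the value of compound 3, which carries isobutyl. No step beyond the scatter is therefore expected in this assay in either direction. The expected change is small (a 1.2-fold lower number from compound 3 to compound 4 (0.07 log units; within the scatter)). Compound 4 is estimated at 350 nM (expected range 120 nM to 1000 nM).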

Compound 4, half-maximal inhibitory concentration in the A2780 assay: 290 nM
Compound 4: middle estimate off by 1.2-fold (0.08 log units), on the high side; the measured number falls inside the stated range.
By their numbers in the A2780 assay, from the lowest: compounds 4, 2 and 3 (each within the scatter of the next). At a limit, above all of these: compound 1.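

In the A2780 assay, the direct exchange of isobutyl for 4-fluorophenyl on a carbonyl carbon gives a 1.4-fold lower number from compound 3 to compound 4 (0.15 log units; within the scatter), so a branched chain and a six-membered aromatic ring read level at this position. Also in the A2780 assay, ethyl in place of cyclopropyl on an amine nitrogen in a ring gives a 1.3-fold lower number from compound 2 to compound 4 (0.12 log units; within the scatter), while the large step comes with 1-ethylpiperidin-4-yl in place of 4-acetylpiperazin-1-yl on a carbonyl carbon, an at least 34-fold lower number from compound 1 to compound 4 (1.53 log units; beyond the scatter). In a physicochemical assay for solubility, at pH 7 (a lower number here means a less soluble compound, a higher number a more soluble compound), compound 3 gives > 225000 nM, which is a limit of the assay. In the physicochemical assay, compound 4 gives > 225000 nM, which is also a limit of the assay. In the physicochemical assay, the step for the isobutyl exchange cannot be read, because compound 3 and compound 4 both sit at a limit of the assay: the limit of > 225000 nM in the physicochemical assay, at which 2 of the 2 values shown sit.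

As far as these compounds go, whether an amine, a carboxylic acid or a longer chain on this carbonyl carbon would also read level stays open. Also open, from the compounds shown here alone, is how isobutyl and 4-fluorophenyl would compare in the physicochemical assay in compounds that give a number rather than a limit.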